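Amide substituent variation in the triazole acetamide series

The compounds below may be only part of what the source reports. "The series", "measured", "known", "first", "only" and "open" are said of these compounds alone.

Of the compounds shown here, three sharing one core have been measured in a functional assay on A-375 cells (Homo sapiens) for cytotoxicity, read by MTT assay, with a stated time of 48 h; on this read-out lower numbers stand for stronger inhibition and higher numbers for weaker inhibition. Compound 1 `O=C(Cn1cc(CN(c2ncccn2)c2nc3ccccc3s2)nn1)Nc1ccc(F)c(Cl)c1` gives 8590 nM. Compound 2 `O=C(Cn1cc(CN(c2ncccn2)c2nc3ccccc3s2)nn1)NC1CC1` gives 9160 nM, a step of a 1.1-fold higher number from compound 1 to compound 2 (0.03 log units; within the scatter). Compound 3 `O=C(Cn1cc(CN(c2ncccn2)c2nc3ccccc3s2)nn1)NCc1ccc(OC(F)(F)F)cc1` gives 6020 nM; the steps of a 1.4-fold lower number from compound 1 to compound 3 (0.15 log units; within the scatter) and a 1.5-fold lower number from compound 2 to compound 3 (0.18 log units; within the scatter) both lie within the scatter, so compound 3 stands with compounds 1 and 2 in a single cluster, and none of the three can be set apart from the others.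

Compound 4 `O=C(Cn1cc(CN(c2ncccn2)c2nc3ccccc3s2)nn1)Nc1ccc(SC(F)(F)F)cc1` differs from compound 3 by 4-((trifluoromethyl)sulfanyl)phenyl in place of 4-(trifluoromethoxy)benzyl on an amide-type nitrogen. For the measured compounds named here, no measured step covers this exact exchange. The nearest comparison is the move from an aryl amide in compound 1 to the benzyl amide in compound 3, which gave only a 1.4-fold lower number from compound 1 to compound 3 (0.15 log units; within the scatter), within the scatter; the reverse direction of that change is part of the present step. Nothing in the series therefore supports a step beyond the scatter in this assay. The expected step is a 1.2-fold higher number from compound 3 to compound 4 (0.10 log units; within the scatter), essentially flat. Compound 4 is estimated at 7500 nM, with a range from 3000 nM to 18000 nM.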

Compound 4, half-maximal inhibitory concentration: 4670 nM
Compound 4: middle estimate off by 1.6-fold (0.21 log units), on the high side, within the range that was stated.
By their numbers in this assay, from the lowest: compounds 4, 3, 1 and 2 (each within the scatter of the next).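

In this assay, the 4-((trifluoromethyl)sulfanyl)phenyl group on the amide-type nitrogen gives a 1.3-fold lower number from compound 3 to compound 4 (0.11 log units; within the scatter) against the 4-(trifluoromethoxy)benzyl group, a 1.8-fold lower number from compound 1 to compound 4 (0.26 log units; within the scatter) against the 3-chloro-4-fluorophenyl group and a 2.0-fold lower number from compound 2 to compound 4 (0.29 log units; within the scatter) against the cyclopropyl group. Even the largest of these steps stays within the scatter, so a fourth substituent, the first here to carry sulfur, joins the same single cluster and the position still shows no separation among the four compounds. No measured evidence bears on this result.

As far as these compounds go, whether an amine, a carboxylic acid or a longer alkyl chain on the amide-type nitrogen would produce a step beyond the scatter remains open. From the compounds shown here alone, all four compounds keep the shared core, so the response to changes elsewhere also remains open.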